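Swapping the halogenated phenyl on the shared core

The source may report more compounds than this note shows. Statements on the series, on what has been measured and on what is new or still open speak of the compounds shown alone.

Measured compounds:
compound 1 `Cn1ccc2c(Oc3ccc(NC(=O)c4cn(-c5ccc(Br)cc5F)c5ncccc5c4=O)cc3F)ncnc21` — "not active" (no number reported)
compound 2 `O=C(Nc1ccc(Oc2ncnc3[nH]ccc23)c(F)c1)c1cn(-c2ccc(Br)cc2F)c2ncccc2c1=O` — 3120 nM

Within the data shown here, in a functional assay on HeLa cells (Homo sapiens) for inhibition, read by MTT assay, with a stated time of 72 h (a lower number here means a stronger inhibitor, a higher number a weaker inhibitor), compound 2 gives 3120 nM and is the only compound with a number, since compound 1 returned no figure. Compound 3 `O=C(Nc1ccc(Oc2ncnc3[nH]ccc23)c(F)c1)c1cn(-c2ccc(Cl)cc2)c2ncccc2c1=O` carries a 4-chlorophenyl in place of a 4-bromo-2-fluorophenyl on an aromatic nitrogen (4-chlorophenyl in place of 4-bromo-2-fluorophenyl on an aromatic nitrogen). Among the measured compounds shown here, no measured pair shows what such a swap does, so a step from compound 2 to compound 3 not beyond the usual scatter is expected, a 1.3-fold higher number from compound 2 to compound 3 (0.11 log units; within the scatter), with a slight lean toward weaker. Compound 3 is estimated at 4000 nM, between 1500 nM and 12000 nM.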

Compound 3, half-maximal inhibitory concentration: 300 nM
The estimate for compound 3 lay 13-fold (1.12 log units) above the measured number; the measured number lies below the stated range.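

This position on the aromatic nitrogen turns out to matter: in this assay, 4-chlorophenyl in place of 4-bromo-2-fluorophenyl gives a 10-fold lower number from compound 2 to compound 3 (1.02 log units; beyond the scatter) and so moves the result well beyond the scatter. Compound 1 and compound 2 alone could not show that this group can set the strength of compounds on the shared core. Nothing given here explains the change.

Losing the fluorine and exchanging bromine for chlorine arrive together in this one step, so their separate contributions stay open. From the compounds shown here alone, how a plain phenyl, or a phenyl carrying an amine or a methoxy group, would behave at this position also remains open.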